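The compounds below may be only part of what the source reports. "The series", "measured", "known", "first", "only" and "open" are said of these compounds alone.

Measured so far:
- compound 1, `Cc1c(CCCC(=O)O)c2cccc(/C=C/c3ccc(OCCCCc4c(F)c(F)cc(F)c4F)cc3)c2n1CC(=O)O`: 2.2 nM
- compound 2, `Cc1c(Cl)cccc1CCCCOc1ccc(C#Cc2cccc3c(CCCC(=O)O)c(C)n(CC(=O)O)c23)cc1`: 0.22 nM

Both were tested in a functional assay on CHO-K1 cells for antagonist activity at cysteinyl leukotriene receptor 1 (Homo sapiens), read by fluorescence and calcium flux, with stated times of 30 min and 1 h; on this read-out lower numbers stand for stronger inhibition and higher numbers for weaker inhibition. Compound 1 gives 2.2 nM, the higher of the two numbers; compound 2 gives 0.22 nM, a lower number that lies beyond the usual scatter, so compound 2 is the stronger inhibitor of the two. Compound 3, `Cc1c(CCCC(=O)O)c2cccc(/C=C/c3ccc(OCCCCc4cc(F)c(F)c(F)c4F)cc3)c2n1CC(=O)O`, has not been measured yet. It holds the same atoms as compound 1, joined differently: 2,3,4,5-tetrafluorophenyl in place of 2,3,5,6-tetrafluorophenyl on a saturated chain carbon, four bonds along the chain from an oxygen on an aromatic ring. Only the arrangement of the fluorines on that ring changes. Within the data shown here, no measured pair here shows this kind of change, so its size cannot be read from these data. Compound 3 is therefore expected to land close to compound 1, whose value is 2.2 nM. The expected step is a 1.1-fold higher number from compound 1 to compound 3 (0.06 log units; within the scatter), within the scatter and in no clear direction. The estimate for compound 3 is 2.5 nM, in a range from 1 nM to 6 nM.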

Compound 3, half-maximal inhibitory concentration in the cysteinyl leukotriene receptor 1 assay: 0.8 nM
Compound 3: the middle estimate sits 3.1-fold (0.49 log units) above what was measured; measured number outside the range, below it.
By their numbers in the cysteinyl leukotriene receptor 1 assay, from the lowest: compound 2; then compound 3; then compound 1.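

In the cysteinyl leukotriene receptor 1 assay, swapping 2,3,5,6-tetrafluorophenyl for 2,3,4,5-tetrafluorophenyl gives a 2.8-fold lower number from compound 1 to compound 3 (0.44 log units; beyond the scatter) and so shows that, at this place on the chain, the arrangement of the fluorines alone can shift the number, with no atom gained or lost. In a physicochemical assay for permeability, using PAMPA, with a stated time of 4 h, at pH 7.4, tested at 50 uM (on this read-out lower numbers stand for lower permeability and higher numbers for higher permeability), compound 1 gives 0.5 10^-6 cm/s and compound 3 gives 0.3 10^-6 cm/s and this pair, at a 1.7-fold lower number from compound 1 to compound 3 (0.22 log units; within the scatter) shows no clear change in apparent permeability. Nothing available explains why the rearrangement shifts the inhibition number.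

Still open, on these data alone, is how a plain phenyl or a pentafluorophenyl ring would compare at this same place, and whether a longer chain would keep the gain. The compounds shown also leave open whether other arrangements of the fluorines would go further in the same direction.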